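The compounds below may be only part of what the source reports. "The series", "measured", "known", "first", "only" and "open" are said of these compounds alone.

Compound 1 `O=C(CCc1cccnc1)Nc1ccc(CN2C(=O)c3ccccc3C2=O)cc1`: > 10000 nM, a limit of the assay
Compound 2 `O=C(/C=C/c1cccnc1)Nc1ccc(CN2C(=O)c3ccccc3C2=O)cc1`: "not determined" (no result reported)
Compound 3 `O=C(Nc1ccc(CN2C(=O)c3ccccc3C2=O)cc1)[C@H]1C[C@@H]1c1cccnc1`: 27 nM

In a functional assay on A2780 cells (Homo sapiens) for antiproliferative activity, read by CellTiter-Glo, with a stated time of 4 days (on this read-out lower numbers stand for stronger inhibition and higher numbers for weaker inhibition), compound 3 gives 27 nM. For the measured compounds named here, this is the only actual number in the set, since the other two entries are a limit and an entry without a result.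

The next compound, compound 4 `O=C(Nc1ccc(CN2C(=O)c3ccccc3C2=O)cc1)[C@@H]1C[C@H]1c1cccnc1`, has the same atoms and bonds as compound 3 and is its mirror image: the two compounds have the same atoms and bonds and differ only in configuration as drawn: 2 of 2 stereo elements differ (all stereocentres are inverted: mirror images); a stereocentre at a saturated ring carbon is drawn S in compound 3 and R in compound 4; a stereocentre at a saturated ring carbon is drawn S in compound 3 and R in compound 4.

Going by the values given here, no measured pair in the set isolates a change of configuration. Among the compounds with values here, the one measured step with a bearing on it is an at least 370-fold lower number from compound 1 to compound 3 (2.56 log units; beyond the scatter). That step replaces the group on the carbonyl carbon and shows that this assay can respond very strongly to a change there. It gives no direct size for inversion, so the expectation remains loose: a loss of activity, meaning a higher number, smaller than that step but probably beyond the scatter. The expected change is a 7.4-fold higher number from compound 3 to compound 4 (0.87 log units; beyond the scatter). For compound 4 the estimated value is 200 nM, with an expected range of 20 nM to 2500 nM.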

Compound 4, half-maximal inhibitory concentration: > 2500 nM
Compound 4 gave a limit, no number; the forecaster's own chance of this, stated with the estimate: 10%; at least 12-fold (1.09 log units) between middle value and limit.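

In this assay, inverting both stereocentres of the 2-(pyridin-3-yl)cyclopropyl group gives an at least 92-fold higher number from compound 3 to compound 4 (1.96 log units; beyond the scatter). Compound 4 reads > 2500 nM, which is a limit of the assay and not a number. The earlier compounds showed that this position responds to a change of group, whereas this pair shows that the 2-(pyridin-3-yl)cyclopropyl group is not enough by itself and that the configuration as drawn also decides the result, with nothing else to account for the difference: the fact that compounds 3 and 4 differ only in the configuration as drawn

The step from compound 1 to compound 4 cannot be read. On these data alone, it also remains open how a compound with only one stereocentre inverted would read, and whether a phenyl ring in place of the pyridin-3-yl ring would keep the activity of compound 3.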